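Step from compound 3 to compound 4 in an indole series

A few compounds are considered here, and "the series" means these few. Any claim that something is new, unique, unknown or untested is made for them only; others in the source may bear on it.

Compound 1 `Cc1cc2ncn(CCCCN3CCN(C(c4ccccc4)c4ccccc4)CC3)c2cc1C`: 770 nM
Compound 2 `Cc1cccc2c1ccn2CCCCN1CCN(C(c2ccccc2)c2ccccc2)CC1`: 5300 nM
Compound 3 `N#Cc1cn(CCCCN2CCN(C(c3ccccc3)c3ccccc3)CC2)c2ccccc12`: 1500 nM

In an assay on RPMI-8226 cells for antagonist activity at P2X purinoceptor 7 (Homo sapiens), read by calcium flux (on this read-out lower numbers stand for stronger inhibition and higher numbers for weaker inhibition), compound 3 stands second highest of the three, with compound 1 nearest (a 1.9-fold higher number from compound 1 to compound 3 (0.29 log units; within the scatter)) and compound 2 furthest (a 3.5-fold lower number from compound 2 to compound 3 (0.55 log units; beyond the scatter)). Compound 4 `Fc1cccc2c1ccn2CCCCN1CCN(C(c2ccccc2)c2ccccc2)CC1` differs from compound 3 by a group of 10 heavy atoms (8 carbon, 1 nitrogen, 1 fluorine; one five-membered aromatic ring with 1 hetero atom, one six-membered aromatic ring of carbon only) in place of a group of 11 heavy atoms (9 carbon, 2 nitrogen; one five-membered aromatic ring with 1 hetero atom, one six-membered aromatic ring of carbon only), on a saturated chain carbon, four bonds along the chain from an amine nitrogen in a ring; the group that leaves carries the triple bond, and a 4-fluoro-1H-indol-1-yl enters. Going by the values given here, the relevant steps are a 6.9-fold higher number from compound 1 to compound 2 (0.84 log units; beyond the scatter) and a 3.5-fold lower number from compound 2 to compound 3 (0.55 log units; beyond the scatter): compound 2, the only other compound bearing a substituent on the six-membered ring of the indole, gave the weakest result. Compound 4 is therefore expected to shift modestly toward weaker inhibition, an estimated 2.3-fold higher number from compound 3 to compound 4 (0.37 log units; beyond the scatter). The estimate for compound 4 is 3500 nM, within 1200 nM to 10000 nM.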

Compound 4, half-maximal inhibitory concentration: 150 nM
Compound 4: middle estimate off by 23-fold (1.37 log units), on the high side; the measured number lies below the stated range.
By their numbers in this assay, from the lowest: compound 4; then compounds 1 and 3 (each within the scatter of the next); then compound 2.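

In this assay, going by these compounds alone, the exchange of methyl for fluoro on an aromatic carbon gives a 35-fold lower number from compound 2 to compound 4 (1.55 log units; beyond the scatter) and is the only change here confined to that single substituent, so a substituent on this ring does not by itself weaken inhibition. The 4-fluoro-1H-indol-1-yl group also gives a 10-fold lower number from compound 3 to compound 4 (1.00 log units; beyond the scatter) and a 5.1-fold lower number from compound 1 to compound 4 (0.71 log units; beyond the scatter) and so places compound 4 lowest of the four. No evidence is at hand to account for these steps. The compounds shown leave open whether chloro or methoxy in place of fluoro would match it, and whether the result holds with a longer chain.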